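The source may report more compounds than this note shows. Statements on the series, on what has been measured and on what is new or still open speak of the compounds shown alone.

Compound 1 `Cc1ccc2[nH]c(=O)c(-c3nc4ccccc4[nH]3)cc2c1` is one of three measured analogues built on a shared core. In a functional assay on NCI-H460 cells (Homo sapiens) for cytotoxicity, read by MTT assay, with a stated time of 48 h (on this read-out higher numbers stand for weaker inhibition and lower numbers for stronger inhibition), compound 1 gives only a limit, > 100000 nM. Compound 2 `COc1ccc2[nH]c(=O)c(-c3nc4ccccc4[nH]3)cc2c1` carries a methoxy in place of the methyl, and in this assay compound 2 likewise reaches only a limit, > 100000 nM. Compound 3 `Cc1cc2nc(-c3cc4ccccc4[nH]c3=O)[nH]c2cc1C` carries its methyl groups differently, and in this assay compound 3 also stops at a limit, > 100000 nM. Going by the values given here, the single comparable step, a step that the two limits leave unreadable from compound 1 to compound 2, cannot be sized because of the limit of > 100000 nM in this assay, at which 3 of the 3 values shown sit. Compound 4 `Cc1ccc2[nH]c(=O)c(-c3nc4cc(Br)ccc4[nH]3)cc2c1` is the untested member; it differs from compound 1 by bromo in place of hydrogen on an aromatic carbon. Among the compounds with values here, no measured step shows how such a change acts here; all three companions sit at the same ceiling, so nothing points to a gain or a loss beyond the scatter. The expectation for compound 4 in this assay is therefore again a value at or past the limit, estimated at 150000 nM with a range from 30000 nM to 1000000 nM. The estimated step is a step that the limit leaves unreadable from compound 1 to compound 4, which amounts to nothing readable.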

Compound 4, half-maximal inhibitory concentration: > 100000 nM
Compound 4 ended at the assay's limit; the forecaster's own chance of this, stated with the estimate: 70%; the middle value lies beyond the limit too.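

In this assay compound 4 gives > 100000 nM, which is a limit and not a number. The change from compound 1 to compound 4 therefore cannot be sized, because both compounds stop at the same limit: the limit of > 100000 nM in this assay, at which 4 of the 4 values shown sit. The compounds shown leave open whether any change to the shared core would give a readable value in this assay.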